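A few compounds are considered here, and "the series" means these few. Any claim that something is new, unique, unknown or untested is made for them only; others in the source may bear on it.

The measured compounds in a functional assay on the whole organism (strain Wistar albino) for inhibition, with Rattus norvegicus as the target, read by paw edema, with a stated time of 1 h, at a dose of 40 mg/kg by the oral route; on this read-out higher numbers stand for more inhibition at the one dose given (going by the name of the read-out) and lower numbers for less inhibition:
compound 1 `Cc1nc(-c2ccc(Cl)cc2)sc1C1SCC(=O)N1c1ccc(F)c(Cl)c1` — 53.4%
compound 2 `Cc1nc(-c2ccc(Cl)cc2)sc1C1SCC(=O)N1c1ccc(Cl)cc1` — 69.3%
compound 3 `Cc1nc(Cc2ccc(Cl)cc2)sc1C1SCC(=O)N1c1ccccc1` — "not active" (no number reported)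

Compound 1 stands lowest of the two numbers in this assay; compound 2 lies a number 15.9 percentage points higher from compound 1 to compound 2 (beyond the scatter). Compound 3 was reported as not active, without a number.

Compound 4 `COc1ccc(N2C(=O)CSC2c2sc(-c3ccc(Cl)cc3)nc2C)cc1` differs from compound 1 only by 4-methoxyphenyl in place of 3-chloro-4-fluorophenyl on an amide-type nitrogen in a ring. Among the measured compounds shown here, the one measured step at this position, a number 15.9 percentage points higher from compound 1 to compound 2 (beyond the scatter), was upward and modest when a 4-chlorophenyl replaced the 3-chloro-4-fluorophenyl. For the measured compounds named here, no measured compound carries a 4-methoxyphenyl, so that step is only a loose guide. Compound 4 is therefore expected to sit near or somewhat above compound 1, an estimated a number 6.6 percentage points higher from compound 1 to compound 4 (within the scatter), giving 60% with a range from 45% to 75%.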

Compound 4, a percentage reported as inhibition, in the whole organism at one dose (the size of the read-out at that dose, not a potency): 54%
Estimate against measurement, compound 4: 6 percentage points above; measured number inside the range.
By their numbers in this assay, from the lowest: compounds 1 and 4 (each within the scatter of the next); then compound 2.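

In this assay, the step of a number 0.6 percentage points higher from compound 1 to compound 4 (within the scatter) shows that 4-methoxyphenyl and 3-chloro-4-fluorophenyl on the amide-type nitrogen cannot be told apart. By contrast, methoxy in place of chloro on the aromatic carbon gives a number 15.3 percentage points lower from compound 2 to compound 4 (beyond the scatter), so the number at this position depends on the group, and 4-chlorophenyl stands out from the other two. No available evidence bears on why these groups differ. From the compounds shown here alone, it remains open whether an amine or a carboxylic acid on this aromatic ring would match compound 2 or compound 4.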